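The source may report more compounds than this note shows. Statements on the series, on what has been measured and on what is new or still open speak of the compounds shown alone.

Measured compounds:
compound 3 `CCc1cnc(N2CCC(c3nc(COc4ccc(/C=C5\CC(=O)NC5=O)cc4)cs3)CC2)nc1` — in a functional assay on cells for agonist activity at Glucose-dependent insulinotropic receptor (Homo sapiens), read by a luciferase reporter, with a stated time of 6 h (on this read-out higher numbers stand for an effect only at larger amounts of compound and lower numbers for an effect already at smaller amounts), compound 3 gives 182 nM.
compound 1 `CC(C)(O)CN1CCC(c2nc(COc3ccc(/C=C4\CC(=O)NC4=O)cc3)cs2)CC1` — in this assay compound 1 gives "not determined" (no result reported).
compound 2 `NCCNC(=O)CCc1cnc(N2CCC(c3nc(COc4ccc(-n5cnnn5)cc4)cs3)CC2)nc1` — in this assay compound 2 gives "not determined" (no result reported).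

Going by the values given here, compound 3 stands alone: it carries the only number in this set, while compound 1 and compound 2 have no result at all. Among the compounds with values here, with only one measured value, there is no step between two measured compounds to learn from.

Compound 4 `CCc1cnc(N2CCC(c3nc(COc4ccc(-n5cnnn5)cc4)cs3)CC2)nc1` differs from compound 3 in a single place: a group of 5 heavy atoms (1 carbon, 4 nitrogen; one five-membered aromatic ring with 4 hetero atoms) in place of a group of 8 heavy atoms (5 carbon, 1 nitrogen, 2 oxygen; one five-membered non-aromatic ring with 1 hetero atom), on an aromatic carbon. Compound 2 carries the entering group and compound 1 the leaving group, but neither has a number, so nothing measured shows what this exchange does in this assay.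

The step of a 2.5-fold higher number from compound 3 to compound 4 (0.39 log units; beyond the scatter) is expected to be a modest weakening, somewhat beyond the usual scatter, since the smaller aromatic group replaces a larger group with a hydrogen-bond donor. Compound 4 is estimated at 450 nM, with a range from 120 nM to 2000 nM.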

Compound 4, half-maximal effective concentration: 87 nM
Estimate against measurement, compound 4: 5.2-fold (0.71 log units) above; the measured number lies below the stated range.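

At this place, on an aromatic carbon para to a large group, the exchange of the non-aromatic ring group for 1H-tetrazol-1-yl gives a gain rather than a loss in this assay (a 2.1-fold lower number from compound 3 to compound 4 (0.32 log units; beyond the scatter)), a modest step but one beyond the scatter. For this pair, then, neither the larger group nor its hydrogen-bond donor is needed for the effect, as the entering group is smaller and has no such donor. Nothing at hand explains why the number falls.

One pair cannot show which feature of the 1H-tetrazol-1-yl group matters, and a carboxylic acid or a primary amide at the same place would help to separate them. From the compounds shown here alone, it also remains open whether the step would be the same in a compound with a longer chain in place of the ethyl group.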